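Bromo for isopropyl: a permeability note

A few compounds are considered here, and "the series" means these few. Any claim that something is new, unique, unknown or untested is made for them only; others in the source may bear on it.

Of the compounds shown here, two have been measured in an ADME assay for permeability, using PAMPA, at pH 7.4; on this read-out lower numbers stand for lower permeability and higher numbers for higher permeability. Compound 1 `Cc1[nH]c2ccc(Cl)cc2c(=O)c1Br` gives 87.7 10^-6 cm/s, and compound 2 `COc1cc2[nH]c(C)c(C(C)C)c(=O)c2cc1Cl` gives 187 10^-6 cm/s. Compound 2 has the higher of the two numbers, and its gap to compound 1 lies beyond the scatter.

The next compound to be read is compound 3 `COc1cc2[nH]c(C)c(Br)c(=O)c2cc1Cl`. It is compound 2 with bromo in place of isopropyl on an aromatic carbon. Among the compounds with values here, no measured pair shows this change on its own, so the series offers no direct step for this assay. Within the data shown here, the only guide is compound 1, which also carries a bromo and gives 87.7 10^-6 cm/s, although its core differs from that of compound 3 elsewhere. One compound is thin support, so the direction is held loosely. A fall near the edge of the scatter is expected, and the estimated step is a 1.9-fold lower number from compound 2 to compound 3 (0.27 log units; within the scatter). For compound 3 the estimated value is 100 10^-6 cm/s, with an expected range from 45 10^-6 cm/s to 210 10^-6 cm/s.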

Compound 3, apparent permeability: 152 10^-6 cm/s
Compound 3: the middle estimate sits 1.5-fold (0.18 log units) below what was measured, within the range that was stated.
By their numbers in this assay, from the lowest: compounds 1, 3 and 2 (each within the scatter of the next, the first and the last beyond it).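

In this assay, within the data shown here, the first single-change pair at this position gives a 1.2-fold lower number from compound 2 to compound 3 (0.09 log units; within the scatter) for bromo in place of isopropyl, on the aromatic carbon ortho to a methyl group. On this read-out the two groups cannot be told apart here, a point compounds 1 and 2 alone could not settle, as they differ in more than one place. The second pair, methoxy in place of hydrogen on an aromatic carbon, gives a 1.7-fold higher number from compound 1 to compound 3 (0.24 log units; within the scatter) and so likewise leaves the two compounds indistinguishable, though each conclusion rests on one pair in one setting.

The measurements in hand offer no independent data that would explain either step.

Still open, from the compounds shown here alone, is whether a group of a different kind at the bromo position, such as an amine or a carboxylic acid, would separate from compound 3 by more than the scatter. Also open, going by these compounds, is whether methoxy in place of hydrogen would read the same with isopropyl rather than bromo on the shared core.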